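From 3-chlorophenyl to 4-methoxyphenyl: compound 2 to compound 3

This account rests on a few compounds, and the source may have more. Where it says the series, first, only, none or still open, it means among the compounds named here.

- Compound 1 `COc1cc(OC)c(C(=O)/C=C/c2cccc(N3CCNCC3)c2)c(O)c1CC=C(C)C`: 99900 nM
- Compound 2 `COc1cc(OC)c(C(=O)/C=C/c2cccc(Cl)c2)c(O)c1CC=C(C)C`: 59500 nM

In an ADME assay on MCF7-DOX cells (Homo sapiens) for cytotoxicity, read by MTT assay, with a stated time of 48 h (a higher number here means a weaker inhibitor, a lower number a stronger inhibitor), compound 2 gives 59500 nM, a number that cannot be told apart from that of compound 1 at 99900 nM. Among the compounds with values here, the only measured step is a 1.7-fold lower number from compound 1 to compound 2 (0.23 log units; within the scatter), with chloro in place of piperazin-1-yl on an aromatic carbon.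

Compound 3 `COc1ccc(/C=C/C(=O)c2c(OC)cc(OC)c(CC=C(C)C)c2O)cc1` is reached by a different exchange: 4-methoxyphenyl in place of 3-chlorophenyl on a double-bonded chain carbon bound to a double-bonded chain carbon. Within the data shown here, no measured compound carries 4-methoxyphenyl, so that single step within the scatter is the only guide, and it bears on the change only loosely. No shift beyond the scatter is therefore expected in this assay. The estimated step is a 1.0-fold higher number from compound 2 to compound 3 (0.00 log units; within the scatter). Compound 3 is expected at 60000 nM, with an estimated range of 25000 nM to 120000 nM.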

Compound 3, half-maximal inhibitory concentration: 46900 nM
Compound 3: middle estimate off by 1.3-fold (0.11 log units), on the high side; the measured number falls inside the stated range.
By their numbers in this assay, from the lowest: compounds 3, 2 and 1 (each within the scatter of the next, the first and the last beyond it).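

In this assay, the exchange of 3-chlorophenyl for 4-methoxyphenyl on a double-bonded chain carbon bound to a double-bonded chain carbon gives a 1.3-fold lower number from compound 2 to compound 3 (0.10 log units; within the scatter) and so stays within the scatter. This is the first step shown at this place that brings in oxygen and removes chlorine, and this assay does not tell the two groups apart. Nothing on hand accounts for how close the two numbers lie.

The exchange alters both the substituent and its printed ring number, so 3-methoxyphenyl or 4-chlorophenyl would be needed to read these two parts separately. On these data alone, whether a phenyl carrying a carboxylic acid or a longer alkoxy chain at this place would give a step beyond the scatter also stays open.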